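Chloro in place of methyl: compound 3 to compound 4

The source may report more compounds than this note shows. Statements on the series, on what has been measured and on what is new or still open speak of the compounds shown alone.

Three compounds of one shared core have numbers in a functional assay on the whole organism (strain Wistar albino) for inhibition, with Rattus norvegicus as the target, read by paw edema, with a stated time of 2 h, at a dose of 25 mg/kg by the oral route; on this read-out higher numbers stand for more inhibition at the one dose given (going by the name of the read-out) and lower numbers for less inhibition. Compound 1 `CSc1nn(-c2ccc([N+](=O)[O-])cc2)c2nc(Nc3ccccc3)n(-c3ccccc3)c(=O)c12` gives 37.7%. Compound 2 `O=c1c2c(Nc3ccccc3)nn(-c3ccc([N+](=O)[O-])cc3)c2nc(Nc2ccccc2)n1-c1ccccc1` gives 40.8%. Compound 3 `Cc1ccc(Nc2nn(-c3ccc([N+](=O)[O-])cc3)c3nc(Nc4ccccc4)n(-c4ccccc4)c(=O)c23)cc1` gives 39.8%. The step of a number 3.1 percentage points higher from compound 1 to compound 2 (within the scatter) and the step of a number 2.1 percentage points higher from compound 1 to compound 3 (within the scatter) both lie within the scatter, as does the step of a number 1 percentage points lower from compound 2 to compound 3 (within the scatter); none of the three compounds can be set apart from the others on these numbers. Compound 3 stands second highest of the three, with compound 2 nearest and compound 1 furthest, both gaps within the scatter.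

Compound 4 `O=c1c2c(Nc3ccc(Cl)cc3)nn(-c3ccc([N+](=O)[O-])cc3)c2nc(Nc2ccccc2)n1-c1ccccc1` is not yet measured. It differs from compound 3 in one place: chloro in place of methyl on an aromatic carbon. Within the data shown here, no measured step exchanges chloro for methyl, so no step bears on this change directly. The nearest comparison is the step of a number 1 percentage points lower from compound 2 to compound 3 (within the scatter), which put methyl in place of hydrogen on an aromatic carbon and stayed within the scatter; the exchanges of the methylsulfanyl group likewise stayed within the scatter. On that footing no step beyond the scatter is expected in this assay in either direction. The expected step is a number 0.2 percentage points higher from compound 3 to compound 4 (within the scatter). For compound 4 the estimate is 40%, with a range from 30% to 50%.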

Compound 4, a percentage reported as inhibition, in the whole organism at one dose (the size of the read-out at that dose, not a potency): 39%
Compound 4: the middle estimate sits 1 percentage points above what was measured; the range from low to high includes it.
By their numbers in this assay, from the lowest: compounds 1, 4, 3 and 2 (each within the scatter of the next).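

Working notes: in this assay the aromatic carbon para to a large group now carries hydrogen, methyl or chloro, and the exchanges at this place give a number 0.8 percentage points lower from compound 3 to compound 4 (within the scatter) and a number 1.8 percentage points lower from compound 2 to compound 4 (within the scatter), so chloro cannot be set apart from either methyl or hydrogen there. The exchange at the other end of the series gives a number 1.3 percentage points higher from compound 1 to compound 4 (within the scatter), so the (4-chlorophenyl)amino group also cannot be set apart from methylsulfanyl, and all four compounds remain indistinguishable in this read-out despite the new halogen. No measured information available here accounts for this flat picture at the position.

Still open, going by these compounds, is whether a carboxylic acid, a dimethylamino group or a longer alkyl chain on the same aromatic carbon would give a step beyond the scatter, since hydrogen, methyl and chloro cover only small groups at this place. Also open, on these data alone, is whether the 4-nitrophenyl group elsewhere on the shared core can be exchanged for an unsubstituted phenyl or a methoxy-bearing phenyl without a step beyond the scatter, and a read-out at one dose gives no potency for any of the four compounds.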